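The source may report more compounds than this note shows. Statements on the series, on what has been measured and on what is new or still open speak of the compounds shown alone.

Compound 1 `COc1c(NS(=O)(=O)c2ccc(F)cc2)cc(-c2ccc3nc(NC4CC4)sc3n2)cc1C(N)=O` carries a cyclopropyl on the nitrogen attached to its aromatic ring. In a functional assay on A549 cells (Homo sapiens) for antiproliferative activity, read by MTT assay, with a stated time of 72 h (on this read-out higher numbers stand for weaker inhibition and lower numbers for stronger inhibition), compound 1 gives 30300 nM, the highest of the two numbers measured here. Compound 2 `COc1c(NS(=O)(=O)c2ccc(F)cc2)cc(-c2ccc3nc(NC(C)=O)sc3c2)cc1C(N)=O`, which carries an acetamido group on a differently arranged core, gives 1700 nM in this assay; the two values lie beyond the scatter. The cores differ as well as the group on the nitrogen, so the gap cannot be attributed to one change alone.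

Compound 3 `COc1c(NS(=O)(=O)c2ccc(F)cc2)cc(-c2ccc3nc(NC(C)=O)sc3n2)cc1C(N)=O` keeps the core of compound 1 and differs from it in one place: acetyl in place of cyclopropyl on a nitrogen on an aromatic ring. Among the compounds with values here, no measured pair isolates this change. The step from compound 1 to compound 3 is expected to go toward stronger inhibition and to reach beyond the scatter, as a 6.1-fold lower number from compound 1 to compound 3 (0.78 log units; beyond the scatter), since compound 2 with the acetamido group gives 1700 nM. Compound 3 is therefore estimated at 5000 nM, within a range of 1500 nM to 20000 nM.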

Compound 3, half-maximal inhibitory concentration: 4310 nM
The estimate for compound 3 lay 1.2-fold (0.06 log units) above the measured number; the range from low to high includes it.
By their numbers in this assay, from the lowest: compound 2; then compound 3; then compound 1.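

With the core held fixed, the group on the nitrogen on an aromatic ring now has a measured effect of its own: putting acetyl in place of cyclopropyl gives a 7.0-fold lower number from compound 1 to compound 3 (0.85 log units; beyond the scatter) in this assay and so stronger inhibition. Both groups count the same number of heavy atoms, so the step does not come with a change in that count; a three-membered carbon ring leaves, and an open acetyl group with a hydrogen-bond acceptor enters. Nothing available here explains why this exchange changes the number.

Going by these compounds, this rests on a single pair, so it remains open whether the same exchange would give a similar step on the core of compound 2. Also unknown is how a free amine, or a longer chain such as propanoyl, would compare at this nitrogen.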